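The source may report more compounds than this note shows. Statements on the series, on what has been measured and on what is new or still open speak of the compounds shown alone.

Measured compounds in an assay on isolated protein for inhibition of protein deacetylase HDAC6 (Homo sapiens), read by fluorescence, tested at 1 uM; on this read-out higher numbers stand for more inhibition at the one concentration tested (going by the name of the read-out) and lower numbers for less inhibition:
- compound 1 `CC(C)(C(=O)Nc1ccc(C(=O)Nc2ccc(F)cc2N)cc1)c1ccccc1` gives 4%
- compound 2 `CC(C)[C@@H](C(=O)Nc1ccc(C(=O)Nc2ccccc2N)cc1)c1ccccc1` gives 16%
- compound 3 `CC(C)[C@@H](C(=O)Nc1ccc(C(=O)Nc2ccc(C(F)(F)F)cc2N)cc1)c1ccccc1` gives 0%

Compound 2 stands highest of the three numbers in this assay; compound 1 lies a step below it that is beyond the scatter, and compound 3 lies furthest, as the step of a number 16 percentage points lower from compound 2 to compound 3 (beyond the scatter) shows, a change brought by a trifluoromethyl in place of hydrogen on an aromatic carbon.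

Compound 4 `CC(C)[C@H](C(=O)Nc1ccc(C(=O)Nc2ccccc2N)cc1)c1ccccc1` differs from compound 2 in this way: the two compounds have the same atoms and bonds and differ only in configuration as drawn: 1 of 1 stereo elements differ; a stereocentre at a saturated chain carbon is drawn R in compound 2 and S in compound 4. Within the data shown here, none of the measured steps concerns a change of configuration; the only step on record, a number 16 percentage points lower from compound 2 to compound 3 (beyond the scatter), changes a substituent and so does not bear on this case. With no guidance from the data, compound 4 is expected to fall near compound 2, with a number 4 percentage points lower from compound 2 to compound 4 (within the scatter) as the expected step, allowing a wide range in either direction. Compound 4 is estimated at 12% in this assay, with a range from 0% to 30%.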

Compound 4, a percentage reported as inhibition, at one concentration (the size of the read-out at that concentration, not a potency): 20%
Compound 4: the middle estimate sits 8 percentage points below what was measured, and the stated range covers the measured number.
By their numbers in this assay, from the lowest: compounds 3 and 1 (each within the scatter of the next); then compounds 2 and 4 (each within the scatter of the next).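

In this assay, among these compounds, this pair gives the first reading of configuration at the saturated chain carbon, and the comparison isolates that one feature: the fact that compounds 2 and 4 differ only in the configuration as drawn. The step, a number 4 percentage points higher from compound 2 to compound 4 (within the scatter), shows that drawing this stereocentre S rather than R leaves the number within the scatter, and the assay does not separate the two forms at the single concentration tested. The earlier step, which changed a substituent on an aromatic carbon, went beyond the scatter, whereas this change of configuration does not.

Going by these compounds, a reading at one concentration gives no potency for either form, and it remains open whether configuration at this carbon would matter with an amine or a longer chain attached there. Also open, on these data alone, is whether the trifluoromethyl change would act on compound 4 as it did on compound 2.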